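The compounds below may be only part of what the source reports. "The series", "measured", "known", "first", "only" and "open" are said of these compounds alone.

In a functional assay on ECa-109 cells (Homo sapiens) for antiproliferative activity, read by MTT assay, with a stated time of 72 h (on this read-out higher numbers stand for weaker inhibition and lower numbers for stronger inhibition), compound 1 `CCCSc1nc(N/N=C/c2cccnc2)c2nnn(Cc3ccccc3)c2n1` gives only a limit, > 64000 nM, and not a number. That is the limit at which one of the three values sits (the limit of > 64000 nM in this assay, at which 1 of the 3 values shown sits), so compound 1 stands at the weak end of what has been measured. Two other compounds from the same series do give numbers: compound 2 `C#CCSc1nc(N/N=C/c2ccc(N(C)C)cc2)c2nnn(Cc3ccccc3)c2n1` gives 31300 nM in this assay, and compound 3 `CCCSc1nc(N/N=C(\C)c2ccccc2O)c2nnn(Cc3ccc(F)cc3)c2n1` gives 21900 nM. Compound 4 `CCCSc1nc(N/N=C/c2ccccc2)c2nnn(Cc3ccccc3)c2n1` has not yet been measured in this assay. It differs from compound 1 in one place (phenyl in place of pyridin-3-yl on a carbon with a double bond to nitrogen). Among the measured compounds shown here, no measured pair differs in only one place, so no measured step is available to guide the expectation. Because compound 1 gives only the limit > 64000 nM, the expectation for compound 4 rests on that limit alone. The step of an at least 1.1-fold lower number from compound 1 to compound 4 (0.06 log units; that floor lies within the scatter) is expected to lie within the scatter or at most a little beyond it, towards stronger inhibition. Compound 4 is therefore estimated to give 55000 nM in this assay, with a range from 22000 nM to 130000 nM.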

Compound 4, half-maximal inhibitory concentration: > 64000 nM
Compound 4 ended at the assay's limit; the forecaster's own chance of this, stated with the estimate: 50%; middle value at least 1.1-fold (0.06 log units) away from the limit.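

Compound 1 and compound 4 both sit at a limit of this assay and give no number, so no step between them can be read: the limit of > 64000 nM in this assay, at which 2 of the 4 values shown sit.

The compounds shown leave open whether phenyl in place of pyridin-3-yl changes inhibition at all in this assay.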